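Replacing a ring-closed terminus with an open diacid chain

The source may report more compounds than this note shows. Statements on the series, on what has been measured and on what is new or still open speak of the compounds shown alone.

Measured compounds:
- compound 1, `C#CCN(Cc1ccc2nc(C)nc(O)c2c1)c1ccc(C(=O)N[C@@H](CCC(=O)O)C(=O)N2CCCC2C(=O)O)cc1`: 35 nM
- compound 2, `C#CCN(Cc1cc2c(O)nc(C)nc2cc1C)c1ccc(C(=O)N[C@@H](CCC(=O)O)C(=O)N(C)[C@@H](CCC(=O)O)C(=O)O)c(F)c1`: 1.1 nM
- compound 3, `C#CCN(Cc1cc2c(O)nc(C)nc2cc1C)c1ccc(C(=O)N[C@@H](CCC(=O)O)C(=O)N(CC#C)[C@@H](CCC(=O)O)C(=O)O)c(F)c1`: 0.21 nM

In an assay on L1210 cells for inhibition of Thymidylate synthase (Mus musculus) (on this read-out higher numbers stand for weaker inhibition and lower numbers for stronger inhibition), compound 1 gives 35 nM, the highest of the three numbers, so it is the weakest inhibitor of the measured set; compound 2 and compound 3, which differ from compound 1 in several places at once, both give markedly lower numbers.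

Compound 4, `C#CCN(Cc1ccc2nc(C)nc(O)c2c1)c1ccc(C(=O)N[C@@H](CCC(=O)O)C(=O)N[C@@H](CCC(=O)O)C(=O)O)cc1`, has not yet been measured. It differs from compound 1 at the terminal carbonyl: (1,3-dicarboxypropyl)amino in place of 2-carboxypyrrolidin-1-yl on a carbonyl carbon. The ring that closes onto the amide-type nitrogen is opened and replaced by an amino acid-like chain carrying two carboxylic acids and an amide hydrogen.

Among the measured compounds shown here, only one single-site step is known here, a 5.2-fold lower number from compound 2 to compound 3 (0.72 log units; beyond the scatter), where a hydrogen on that same amide-type nitrogen was swapped for an alkyne-bearing carbon. It shows that the group attached to this nitrogen matters in this assay, but it does not show what opening the ring and leaving the nitrogen bare will do. The expected step for compound 4 is therefore uncertain, but the lower numbers of compound 2 and compound 3, which share the open diacid terminus, suggest a modest gain.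

Compound 4 is estimated at 15 nM, with a range from 4 nM to 60 nM, corresponding to an expected 2.3-fold lower number from compound 1 to compound 4 (0.37 log units; beyond the scatter).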

Compound 4, inhibition constant: 2 nM
Beside the measured number, compound 4's estimate is 7.5-fold (0.88 log units) above it; measured number below the stated range.
By their numbers in this assay, from the lowest: compound 3; then compounds 2 and 4 (each within the scatter of the next); then compound 1.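

In this assay the step from the 2-carboxypyrrolidin-1-yl group to the (1,3-dicarboxypropyl)amino group on a carbonyl carbon is an 18-fold lower number from compound 1 to compound 4 (1.24 log units; beyond the scatter), so this terminal group has a large effect on the read-out for the core of compound 1. Among the compounds shown here, the only earlier single-site step, a 5.2-fold lower number from compound 2 to compound 3 (0.72 log units; beyond the scatter), changed a group on the amide-type nitrogen while the open diacid chain stayed in place; this new step is the first to replace the ring itself with that chain, and it shows that an open chain keeping the amide hydrogen is compatible with a low number. No independent measurement is available to explain how this exchange produces the change in the number.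

The exchange removes the ring, adds a carboxylic acid and introduces the amide hydrogen all at once, so the compounds shown cannot say which of these changes accounts for the step. An open chain ending in a single carboxylic acid, or a tetrazole in place of one carboxylic acid, would help to separate these contributions at this position.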